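Phenyl on the Lactam Hydroxyl: From Compound 2 to Compound 4

This account rests on a few compounds, and the source may have more. Where it says the series, first, only, none or still open, it means among the compounds named here.

Compound 1 `COc1ccc(C2C(O)C(=O)N2c2cc(OC)c(OC)c(OC)c2)cc1`: 4 nM
Compound 2 `COc1cc(N2C(=O)C(O)C2c2ccc(SC)cc2)cc(OC)c1OC`: 5 nM
Compound 3 `COc1ccc(C2C(O)C(=O)N2c2cc(OC)c(OC)c(OC)c2)cc1O`: 3 nM

In a functional assay on MCF7 cells (Homo sapiens) for inhibition, read by resazurin assay, with a stated time of 72 h (a lower number here means a stronger inhibitor, a higher number a weaker inhibitor), compound 2 gives 5 nM, the highest of the three numbers, yet its neighbours sit close: the nearest lies a 1.3-fold higher number from compound 1 to compound 2 (0.10 log units; within the scatter), the furthest a 1.7-fold lower number from compound 2 to compound 3 (0.22 log units; within the scatter), so the three cannot be ordered. The remaining step, a 1.3-fold lower number from compound 1 to compound 3 (0.12 log units; within the scatter), is likewise small. All three steps change substituents on aromatic rings only. Compound 4 `COc1cc(N2C(=O)C(Oc3ccccc3)C2c2ccc(SC)cc2)cc(OC)c1OC` differs from compound 2 by phenyl in place of hydrogen on an oxygen on a saturated carbon. For the measured compounds named here, no measured step touches this oxygen, so nothing here tells how large the step will be or which way it runs. With that uncertainty, compound 4 is expected to give 40 nM, within 5 nM to 400 nM, an estimated step of an 8.0-fold higher number from compound 2 to compound 4 (0.90 log units; beyond the scatter).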

Compound 4, half-maximal inhibitory concentration: 152 nM
The estimate for compound 4 lay 3.8-fold (0.58 log units) below the measured number, within the range that was stated.
By their numbers in this assay, from the lowest: compounds 3, 1 and 2 (each within the scatter of the next); then compound 4.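

The earlier steps shown here changed only substituents on aromatic rings and all stayed within the scatter, so they said nothing about this oxygen. In this assay, for the compounds shown here, hydroxy to phenoxy gives a 30-fold higher number from compound 2 to compound 4 (1.48 log units; beyond the scatter) and is the only step here beyond the scatter, which shows that this position does not tolerate every change. No measurement shown accounts for the size of this step. Going by these compounds, whether the loss comes with any group replacing this hydrogen or with phenyl in particular stays open. A methyl on this oxygen, or an amine in place of the hydroxy, would begin to separate the two.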